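The source may hold more compounds than are shown below. What is called first, only, known or untested is meant among the compounds shown, and "the series" means these compounds.

Measured in a functional assay on the whole organism (strain Wister albino) for inhibition, with Rattus norvegicus as the target, read by paw edema, with a stated time of 1 h, at a dose of 50 mg/kg by the intraperitoneal route; a lower number here means less inhibition, a higher number more inhibition at the dose given (going by the name of the read-out):

compound 1 `CN1C[C@@H](c2ccccc2)[C@@]2(Cc3ccccc3C2=O)[C@@]12C(=O)Nc1ccccc12`: 56%
compound 2 `CN1C(=O)[C@@]2(c3ccccc31)N(C)C[C@@H](c1ccco1)[C@@]21Cc2ccccc2C1=O`: 50.1%
compound 3 `CN1C(=O)[C@@]2(c3ccccc31)N(C)C[C@@H](c1ccc(Cl)cc1)[C@@]21Cc2ccccc2C1=O`: 47.2%

Compound 1 holds the highest of the three numbers, but its gaps to compound 2 and compound 3 both lie within the scatter, so the three compounds are not separated by this assay. For the measured compounds named here, the only step between measured compounds that differ in one place is a number 2.9 percentage points lower from compound 2 to compound 3 (within the scatter), a change of the aryl group on the saturated ring carbon that leaves the read-out where it was.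

Compound 4 `COc1ccc([C@@H]2CN(C)[C@]3(C(=O)Nc4ccccc43)[C@]23Cc2ccccc2C3=O)cc1` differs from compound 1 by methoxy in place of hydrogen on an aromatic carbon, read one bond further out as phenyl to 4-methoxyphenyl. Going by the values given here, no measured pair shows methoxy in place of hydrogen, so the only guide is the one step on the same aryl group, which stayed within the scatter. On that basis no step beyond the scatter is expected for compound 4, and the estimate is a step of a number 1 percentage points lower from compound 1 to compound 4 (within the scatter). Compound 4 is expected to give 55% in this assay, within a range of 44% to 66%.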

Compound 4, a percentage reported as inhibition, in the whole organism at one dose (the size of the read-out at that dose, not a potency): 41.2%
The estimate for compound 4 lay 13.8 percentage points above the measured number, and the stated range ends above it.
By their numbers in this assay, from the lowest: compounds 4, 3, 2 and 1 (each within the scatter of the next, the first and the last beyond it).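

In this assay, for the compounds shown here, methoxy in place of hydrogen on an aromatic carbon, para to a large group, gives a number 14.8 percentage points lower from compound 1 to compound 4 (beyond the scatter) and is the first one-place change to clear the scatter. The earlier step on this aryl group, a number 2.9 percentage points lower from compound 2 to compound 3 (within the scatter), stayed within it, so that pair gave no sign that this part of the molecule could move the read-out. Phenyl to 4-methoxyphenyl on the core of compound 1 therefore does not leave the read-out in place, though no measurement here accounts for the drop.

Going by these compounds, whether a hydroxyl group or an amine at the same carbon would lower the read-out as well remains open. Also open, on these data alone, is whether methoxy would give a similar step on the core of compound 2.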